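From an Inactive Dichloro Compound to a Bromo-Hydroxy One

This account rests on a few compounds, and the source may have more. Where it says the series, first, only, none or still open, it means among the compounds named here.

In a functional assay on MCF7 cells (Homo sapiens) for antiproliferative activity, read by MTT assay, with a stated time of 72 h (a higher number here means a weaker inhibitor, a lower number a stronger inhibitor), compound 1 `O=C(N/N=C/c1ccccc1)Nc1ccc(Oc2ccnc3[nH]ccc23)c(F)c1` gives 2380 nM, while compound 2 `O=C(N/N=C/c1cccc(Br)c1)Nc1ccc(Oc2ccnc3[nH]ccc23)c(F)c1` gives 49 nM. Putting bromo in place of hydrogen on an aromatic carbon therefore brings a 49-fold lower number from compound 1 to compound 2 (1.69 log units; beyond the scatter), a large step well beyond the usual scatter. Compound 3 `O=C(N/N=C/c1cccc(Cl)c1Cl)Nc1ccc(Oc2ccnc3[nH]ccc23)c(F)c1` stands apart: it is reported as "not active" (no number reported), with no number at all, and so goes against any simple rule that halogens bring activity.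

Compound 4 `O=C(N/N=C/c1ccc(O)c(Br)c1)Nc1ccc(Oc2ccnc3[nH]ccc23)c(F)c1` replaces the group on the carbon with a double bond to nitrogen: 3-bromo-4-hydroxyphenyl in place of 2,3-dichlorophenyl on a carbon with a double bond to nitrogen. Going by the values given here, compound 4 carries a bromo, so the step to compound 2 is the one measured change that bears on it. Among the compounds with values here, no measured compound here carries a hydroxy, which leaves real uncertainty. With no number for compound 3, no step size can be stated, but the expected direction in this assay is from no measurable activity towards measurable activity. The estimate for compound 4 is an expected 200 nM, with an expected range of 30 nM to 1800 nM.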

Compound 4, half-maximal inhibitory concentration: 8230 nM
Compound 4: the middle estimate sits 41-fold (1.61 log units) below what was measured; measured number outside the range, above it.
By their numbers in this assay, from the lowest: compound 2; then compound 1; then compound 4.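

Adding a hydroxy to the bromo-bearing ring of compound 2 reverses the gain seen with the bromo, giving a 170-fold higher number from compound 2 to compound 4 (2.23 log units; beyond the scatter) in this assay. The 3-bromo-4-hydroxyphenyl group also falls behind plain phenyl on the same carbon, with a 3.5-fold higher number from compound 1 to compound 4 (0.54 log units; beyond the scatter), so a bromo on this ring does not bring strong activity regardless of what else the ring carries. Nothing available here accounts for the size of this loss. The compounds shown leave open how a hydroxy behaves on the phenyl ring without a bromo. They also leave open whether a methoxy or an amine in place of the hydroxy would keep the low number of compound 2 or lose it as well.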